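The source may hold more compounds than are shown below. What is called first, only, known or untested is meant among the compounds shown, and "the series" means these compounds.

Two carbamates of the shared core have been run in a functional assay on PANC-1 cells (Homo sapiens) for inhibition, read by MTT assay, with a stated time of 24 h, tested at 10 uM; a lower number here means less inhibition, a higher number more inhibition at the concentration tested (going by the name of the read-out). Compound 1 `CC(C)=CCC1Cc2c(OC(=O)Nc3ccc(Cl)c(Cl)c3)cc(=O)n(CCCO)c2CC1(C)C` gives 61.4%, and compound 2 `CC(C)=CCC/C(C)=C/CC1Cc2c(OC(=O)Nc3ccc(F)cc3)cc(=O)n(CCCO)c2CC1(C)C` gives 43.9%, the lower of the two numbers, with compound 1 its nearest neighbour and that gap beyond the scatter. Compound 1 and compound 2 differ in more than one place, so only their two values are shown and no single step between them is computed. Compound 3 `CC(C)=CCC/C(C)=C/CC1Cc2c(OC(=O)Nc3ccc(Cl)c(Cl)c3)cc(=O)n(CCCO)c2CC1(C)C` keeps the chain of compound 2 and carries the change (3,4-dichlorophenyl in place of 4-fluorophenyl on an amide-type nitrogen). With compound 1 giving 61.4% on the same 3,4-dichlorophenyl group, an upward step is expected for compound 3, estimated as a number 11.1 percentage points higher from compound 2 to compound 3 (beyond the scatter). Compound 3 is then estimated at 55%, with a range from 40% to 70%.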

Compound 3, a percentage reported as inhibition, at one concentration (the size of the read-out at that concentration, not a potency): 20%
Estimate against measurement, compound 3: 35 percentage points above; measured number outside the range, below it.
By their numbers in this assay, from the lowest: compound 3; then compound 2; then compound 1.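

In this assay, 3,4-dichlorophenyl in place of 4-fluorophenyl on an amide-type nitrogen gives a number 23.9 percentage points lower from compound 2 to compound 3 (beyond the scatter), so this change lowers the number on the chain of compound 2. The 3,4-dichlorophenyl group does not fix the value by itself: with it held constant, 3-methylbut-2-en-1-yl in place of hydrogen on a saturated chain carbon bound to a double-bonded chain carbon gives a number 41.4 percentage points lower from compound 1 to compound 3 (beyond the scatter). No measurement shown accounts for either step. Still open, from the compounds shown here alone, is how 4-fluorophenyl reads on the chain of compound 1, and so whether the aryl change runs the same way there. Also open, going by these compounds, is how a 4-chlorophenyl or unsubstituted phenyl group reads on that nitrogen.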